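A few compounds are considered here, and "the series" means these few. Any claim that something is new, unique, unknown or untested is made for them only; others in the source may bear on it.

Compound 1 `COc1ccc(-c2nc3sc(Cc4ccc(Cl)cc4)nn3c2Br)cc1`: in an ADME assay on CCRF-CEM cells (Homo sapiens) for cytotoxicity, with a stated time of 72 h (on this read-out higher numbers stand for weaker inhibition and lower numbers for stronger inhibition), compound 1 gives 58000 nM.
Compound 2 `Cc1ccc(-c2nc3sc(Cc4ccc(Cl)cc4)nn3c2Br)cc1`: compound 2 gives only a limit of this assay, > 250000 nM.
Compound 3 `O=[N+]([O-])c1ccc(-c2nc3sc(Cc4ccc(Cl)cc4)nn3c2Br)cc1`: compound 3 gives 73000 nM.

Compound 3 holds the higher of the two numbers, but the gap to compound 1, a 1.3-fold higher number from compound 1 to compound 3 (0.10 log units; within the scatter), lies within the scatter, so no order between them can be claimed. Compound 2 sits at a limit, (the limit of > 250000 nM in this assay, at which 1 of the 3 values shown sits), and its steps to the others, an at least 4.3-fold higher number from compound 1 to compound 2 (0.63 log units; beyond the scatter) and an at least 3.4-fold lower number from compound 2 to compound 3 (0.53 log units; beyond the scatter), are only lower bounds.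

Compound 4 `O=Cc1c(-c2ccc([N+](=O)[O-])cc2)nc2sc(Cc3ccc(Cl)cc3)nn12` is not yet measured. The change is formyl in place of bromo on an aromatic carbon. Among the measured compounds shown here, all three measured steps alter the group on the phenyl ring, none touches the five-membered ring where the bromo sits, so no measured step bears directly on this change. With nothing to point either way, the expectation is a step no larger than the scatter, no change at the digits printed from compound 3 to compound 4 (within the scatter), though the range must stay wide. Compound 4 is therefore estimated at 73000 nM in this assay, between 20000 nM and 250000 nM.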

Compound 4, half-maximal inhibitory concentration: 13000 nM
Compound 4: the middle estimate sits 5.6-fold (0.75 log units) above what was measured, outside the stated range (below it).
By their numbers in this assay, from the lowest: compound 4; then compounds 1 and 3 (each within the scatter of the next). At a limit, above all of these: compound 2.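

In this assay, the group on the aromatic carbon of the five-membered aromatic ring proves to matter: formyl in place of bromo gives a 5.6-fold lower number from compound 3 to compound 4 (0.75 log units; beyond the scatter). Among the compounds shown here, the earlier steps all altered the group on the phenyl ring, so this is the first sign that the read-out also responds to a change at this other position, here with the nitro group on the phenyl ring held constant. This step is of modest size, and nothing measured here gives a property of either group that would account for it.

For the compounds shown here, the change at this position is seen only with the nitro group on the phenyl ring, so it remains open whether formyl in place of bromo would give a step of similar size and direction with methoxy or methyl there. Going by these compounds, it also remains open how other groups at this position would compare with formyl and bromo, for instance a hydroxymethyl, a carboxylic acid, an amine or a longer chain.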